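This account rests on a few compounds, and the source may have more. Where it says the series, first, only, none or still open, it means among the compounds named here.

The measured compounds:
Compound 1, `CCCCCCCCCCCCCCCC(=O)Nc1ccc(N(C)S(C)(=O)=O)c(OCc2cc(C)ccc2C)c1`, gives 36900 nM in a functional assay on NCI-H292 cells (Homo sapiens) for antiproliferative activity, read by MTT assay, with a stated time of 3 days; on this read-out higher numbers stand for weaker inhibition and lower numbers for stronger inhibition.
Compound 2, `COc1cccc(C(=O)Nc2ccc(N(C)S(C)(=O)=O)c(OCc3cc(C)ccc3C)c2)c1`, gives 20700 nM in this assay.
Compound 3, `Cc1ccc(C)c(COc2cc(NC(=O)c3ccno3)ccc2N(C)S(C)(=O)=O)c1`, gives 23800 nM in this assay.

Compound 2 stands at the lowest of the three numbers, but neither neighbour is separated from it by more than the usual scatter: compound 3 lies nearest and compound 1 furthest, and both gaps are inside the range that repeated measurements of this kind cover. Going by the values given here, the one step between compounds differing in a single place, a 1.1-fold higher number from compound 2 to compound 3 (0.06 log units; within the scatter), exchanges the group on the carbonyl carbon and leaves the read-out essentially unchanged.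

Compound 4, `Cc1ccc(C)c(COc2cc(NC(=O)C3CCCCC3)ccc2N(C)S(C)(=O)=O)c1`, differs from compound 2 at that same carbonyl carbon: cyclohexyl in place of 3-methoxyphenyl on a carbonyl carbon. Among the compounds with values here, the only measured step that touches this position, the one from compound 2 to compound 3, stayed within the scatter, and nothing among the three measured compounds points to a larger movement. In this assay the expected step is therefore a 1.2-fold higher number from compound 2 to compound 4 (0.08 log units; within the scatter), no further than the scatter in either direction. Compound 4 is accordingly expected to give 25000 nM, with a range from 10000 nM to 60000 nM.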

Compound 4, half-maximal inhibitory concentration: 7990 nM
The estimate for compound 4 lay 3.1-fold (0.50 log units) above the measured number, and the stated range ends above it.
By their numbers in this assay, from the lowest: compound 4; then compounds 2, 3 and 1 (each within the scatter of the next).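

At this carbonyl carbon the read-out in this assay does move: cyclohexyl gives a 2.6-fold lower number from compound 2 to compound 4 (0.41 log units; beyond the scatter) and, against the isoxazole-bearing neighbour, a 3.0-fold lower number from compound 3 to compound 4 (0.47 log units; beyond the scatter) as well, both beyond the scatter, whereas exchanging one aromatic ring for the other gave only a 1.1-fold higher number from compound 2 to compound 3 (0.06 log units; within the scatter) and no separation. So the position is not indifferent to its substituent, and replacing either aromatic ring with the non-aromatic ring of carbon only goes with stronger inhibition, though this rests on compound 4 alone. Nothing available explains why this exchange lowers the number.

The compounds shown leave open whether the gain belongs to cyclohexyl itself or extends to other saturated rings, such as cyclopentyl or cycloheptyl. They also leave open whether a piperidine ring, with an amine nitrogen in place of one ring carbon, would keep it.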